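The compounds below may be only part of what the source reports. "The series", "measured", "known", "first", "only" and "open" are said of these compounds alone.

In an assay on a protein complex for binding affinity to Neuronal acetylcholine receptor; alpha4/beta2 (Homo sapiens) (on this read-out lower numbers stand for stronger inhibition and higher numbers for weaker inhibition), compound 1 `CNC1CCCc2ccncc21` reaches only the assay limit of > 10000 nM. Among the measured compounds shown here, compound 2 `CN(C)C1CCCc2ccncc21` gives 330 nM, the only plain number in the set. The other value, that of compound 1, is a limit (the limit of > 10000 nM in this assay, at which 1 of the 2 values shown sits). For the measured compounds named here, the single measured step, an at least 30-fold lower number from compound 1 to compound 2 (1.48 log units; beyond the scatter), is large. Compound 3 `CCCNC1CCCc2ccncc21` is not yet measured; it differs from compound 2 by propylamino in place of dimethylamino on a saturated ring carbon, so the nitrogen again carries a hydrogen, now with a longer chain. Given the size of the step from the methylated nitrogen of compound 1 to compound 2, a step back toward weaker binding is expected for compound 3, a 24-fold higher number from compound 2 to compound 3 (1.38 log units; beyond the scatter). Compound 3 is therefore estimated at 8000 nM, in the range 1500 nM to 40000 nM, with a real chance that only a limit is reported.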

Compound 3, inhibition constant: > 10000 nM
Compound 3: no number, only a limit; the forecaster's own chance of this, stated with the estimate: 40%; middle value at least 1.2-fold (0.09 log units) from the limit.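

Propylamino in place of dimethylamino on the saturated ring carbon gives an at least 30-fold higher number from compound 2 to compound 3 (1.48 log units; beyond the scatter), so a longer chain on a nitrogen that keeps its hydrogen does not recover the binding seen with compound 2. Among the compounds shown, only compound 2, whose nitrogen carries no hydrogen, gives a plain number in this assay. The step between compound 1 and compound 3 cannot be read, since both values are limits: the limit of > 10000 nM in this assay, at which 2 of the 3 values shown sit.

Going by these compounds, whether diethylamino or a pyrrolidine ring at this carbon would keep the binding of compound 2 remains open. Any real difference between compound 1 and compound 3 also remains open.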